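Pentafluorophenyl for bromophenyl on an isoxazolidine-bearing core

The source may hold more compounds than are shown below. What is called first, only, known or untested is meant among the compounds shown, and "the series" means these compounds.

Compound 1 `C[C@H]1CC[C@@H]2[C@@H](OC(=O)[C@]23CC(c2ccc(O)cc2)=NO3)[C@]2(C)C(=O)C=C[C@@]12O`: 0.932
Compound 2 `COc1cc(C2=NO[C@]3(C2)C(=O)O[C@@H]2[C@H]3CC[C@H](C)[C@]3(O)C=CC(=O)[C@@]23C)ccc1O`: 0.75
Compound 3 `C[C@H]1CC[C@@H]2[C@@H](OC(=O)[C@]23CC(c2ccc(Br)cc2)N(c2ccccc2)O3)[C@]2(C)C(=O)C=C[C@@]12O`: 4

Of the compounds shown here, three have been measured in a physicochemical assay for lipophilicity; a higher number here means a more lipophilic compound, a lower number a more polar compound. Going by the values given here, compound 1 gives 0.932 and compound 2 gives 0.75; the only one-place step among them, a number 0.18 log units lower from compound 1 to compound 2 (within the scatter), is a methoxy in place of hydrogen on an aromatic carbon. Compound 3 gives 4 and stands highest of the three, beyond the scatter above compound 1 and further still above compound 2.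

Compound 4 `C[C@H]1CC[C@@H]2[C@@H](OC(=O)[C@]23CC(c2c(F)c(F)c(F)c(F)c2F)N(c2ccccc2)O3)[C@]2(C)C(=O)C=C[C@@]12O` has not yet been measured. It differs from compound 3 in one place: 2,3,4,5,6-pentafluorophenyl in place of 4-bromophenyl on a saturated ring carbon. Among the compounds with values here, no measured step bears directly on this change. Within the data shown here, the single step on record, from compound 1 to compound 2, concerns a different group on a different ring, and its size was within the scatter, so it offers no guidance on the exchange of one halogenated aromatic group for another. With nothing to anchor a shift, compound 4 is expected to stay close to compound 3 in this assay, with a number 0.20 log units lower from compound 3 to compound 4 (within the scatter) as the expected step, not clearly beyond the scatter. Compound 4 is therefore estimated at 3.8, in a range from 3.2 to 4.4.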

Compound 4, partition coefficient: 3.72
Beside the measured number, compound 4's estimate is 0.08 log units above it; low and high end bracket the measured number.
By their numbers in this assay, from the lowest: compounds 2 and 1 (each within the scatter of the next); then compounds 4 and 3 (each within the scatter of the next).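

In this assay, the exchange on a saturated ring carbon of the five-membered ring, next to the ring nitrogen, gives a number 0.28 log units lower from compound 3 to compound 4 (within the scatter). Going by these compounds alone, replacing 4-bromophenyl by 2,3,4,5,6-pentafluorophenyl therefore leaves the read-out within the scatter, and this is the first step on record at this position, as the earlier step concerned a methoxy group on an aromatic carbon. No supporting measurement accompanies this result, so it stands as an observation without an explanation.

Going by these compounds, whether this carbon would show a similarly small step with a group of another kind, such as an unsubstituted phenyl, an amine or a carboxylic acid, remains open. Within the data shown here, compound 3 and compound 4 each differ from compound 1 and compound 2 in more than one place, so no step links the two pairs, and the part played by the phenyl group on the ring nitrogen stays unresolved.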